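Swapping a dibutylamino for a piperidinyl ring

The compounds below may be only part of what the source reports. "The series", "measured", "known", "first", "only" and "open" are said of these compounds alone.

Compound 1, `CCCCCCCCCCCCCC[C@H](OCOC)[C@H](CO)NC(=O)OC(C)(C)C`, in a functional assay on MCF7 cells (Homo sapiens) for antiproliferative activity, read by sulforhodamine B assay, with a stated time of 48 h, tested at 10 uM; a higher number here means more inhibition at the concentration tested (going by the name of the read-out), a lower number less inhibition: 10.2%
Compound 2, `CCCCCCCCCCCCCC[C@H](OCOC)[C@H](CN(C(C)C)C(C)C)NC(=O)OC(C)(C)C`, in this assay: 26.9%
Compound 3, `CCCCCCCCCCCCCC[C@H](OCOC)[C@H](CN(CCCC)CCCC)NC(=O)OC(C)(C)C`, in this assay: 27.1%

Compound 3 holds the highest of the three numbers in this assay, but compound 2 lies within the scatter of it, so the two cannot be ranked against each other. Only compound 1 stands clearly apart, as the steps of a number 16.7 percentage points higher from compound 1 to compound 2 (beyond the scatter) and a number 16.9 percentage points higher from compound 1 to compound 3 (beyond the scatter) show: a modest rise each time a tertiary amine stands in place of hydroxy on the saturated chain carbon two bonds from the amide-type nitrogen. Between the two tertiary amines the step of a number 0.2 percentage points higher from compound 2 to compound 3 (within the scatter) stays within the scatter.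

Compound 4, `CCCCCCCCCCCCCC[C@H](OCOC)[C@H](CN1CCCCC1)NC(=O)OC(C)(C)C`, differs from compound 3 in one place: piperidin-1-yl in place of dibutylamino on a saturated chain carbon, two bonds along the chain from an amide-type nitrogen. The measured step that bears most directly on this exchange is a number 0.2 percentage points higher from compound 2 to compound 3 (within the scatter), which also swapped one tertiary amine for another at the same place and produced no step beyond the scatter. Going by the values given here, compound 4 keeps a tertiary amine, the feature shared by compound 2 and compound 3, and no measured step suggests that the ring form of the amine should matter. Compound 4 is therefore expected to show no step beyond the scatter, a number 0.1 percentage points lower from compound 3 to compound 4 (within the scatter). Compound 4 is estimated at 27%, with a range from 15% to 40%.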

Compound 4, a percentage reported as inhibition, at one concentration (the size of the read-out at that concentration, not a potency): 27.3%
Beside the measured number, compound 4's estimate is 0.3 percentage points below it, and the stated range covers the measured number.
By their numbers in this assay, from the lowest: compound 1; then compounds 2, 3 and 4 (each within the scatter of the next).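

In this assay, the ring form of the amine cannot be told apart from the open-chain forms: a number 0.2 percentage points higher from compound 3 to compound 4 (within the scatter) and a number 0.4 percentage points higher from compound 2 to compound 4 (within the scatter) both stay within the scatter. On this saturated chain carbon, two bonds along the chain from an amide-type nitrogen, piperidin-1-yl therefore reads the same as dibutylamino and diisopropylamino, so tying the amine's substituents into a six-membered non-aromatic ring leaves the reading where the open-chain amines put it. The modest gain over hydroxy also carries over to the ring, with a number 17.1 percentage points higher from compound 1 to compound 4 (beyond the scatter) beyond the scatter, so all three tertiary amines stand clear of compound 1 and none stands clear of another. Nothing available here explains why these amines read alike.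

The compounds shown leave open whether the gain needs a tertiary amine at all, since a primary amine, a morpholine ring or a carboxylic acid at the same place would test that directly. They also leave open how the amines compare as full potencies, since every reading here comes from a single concentration, and whether the same gain would hold with a shorter chain on the core.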